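This account rests on a few compounds, and the source may have more. Where it says the series, first, only, none or still open, it means among the compounds named here.

Within the data shown here, compound 2, `COc1cc(-c2nn(-c3cccc(NC(=O)Nc4cccc(C(F)(F)F)c4)c3)cc2-c2ccncc2)ccc1Cl`, gives 2700 nM in a functional assay on OVCAR-8 cells (Homo sapiens) for inhibition, read by sulforhodamine B assay, with a stated time of 48 h (on this read-out lower numbers stand for stronger inhibition of growth and higher numbers for weaker inhibition of growth), and that is the only number in this set. Compound 1, `COc1cc(-c2nn(-c3cccc(NC(=O)c4cccc(C(F)(F)F)c4)c3)cc2-c2ccncc2)ccc1Cl`, comes out as > 50000 nM in this assay, which is a limit of the measurement rather than a number. Among the measured compounds shown here, the step of an at least 18-fold lower number from compound 1 to compound 2 (1.26 log units; beyond the scatter) is the only measured step, and it rests on that limit (the limit of > 50000 nM in this assay, at which 1 of the 2 values shown sits). Compound 3, `COc1cc(-c2nn(-c3cccc(NC(=O)c4ccc(Cl)c(C(F)(F)F)c4)c3)cc2-c2ccncc2)ccc1Cl`, has not yet been measured. Its change from compound 2 is 4-chloro-3-(trifluoromethyl)phenyl in place of (3-(trifluoromethyl)phenyl)amino on a carbonyl carbon. This largely reverses the measured step, so compound 3 is expected to return toward the weaker end of the measured range. Compound 3 is therefore expected to show a large rise in number, an 11-fold higher number from compound 2 to compound 3 (1.05 log units; beyond the scatter), with a fair chance that this assay again gives only a limit. The estimate for compound 3 is 30000 nM, in a range from 8000 nM to 100000 nM.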

Compound 3, concentration for total growth inhibition: > 32500 nM
Compound 3: only a limit was reported (the forecaster's own chance of this, stated with the estimate: 55%); middle value at least 1.0-fold (0.03 log units) away from the limit.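

In this assay, putting 4-chloro-3-(trifluoromethyl)phenyl on the carbonyl carbon in place of (3-(trifluoromethyl)phenyl)amino gives an at least 12-fold higher number from compound 2 to compound 3 (1.08 log units; beyond the scatter), so a second compound without that amino nitrogen lies on the weak side of compound 2. The result for compound 3 is a limit and not a number: the limit of > 32500 nM in this assay, at which 1 of the 3 values shown sits. Compound 1 and compound 3 both carry limits, so the step between them, the added chloro, cannot be read, and compound 2 remains the only one of the three with a number.

As far as these compounds go, whether that number depends on the amino nitrogen itself stays open, as the set holds no methylene or ether oxygen in its place. Also open, from the compounds shown here alone, is what a chloro on the aromatic ring of compound 2 would do.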